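The source may hold more compounds than are shown below. What is called first, only, known or untested is meant among the compounds shown, and "the series" means these compounds.

Of the compounds shown here, two have been measured in a functional assay on the whole organism (strain Jcl:Sprague-Dawley) for inhibition, with Rattus norvegicus as the target, with stated times of 3 min and 3 h, at a dose of 1 mg/kg by the intravenous route; a lower number here means less inhibition, a higher number more inhibition at the dose given (going by the name of the read-out). Compound 1, `CNCc1cc(-c2cccnc2F)n(S(=O)(=O)c2cccs2)c1`, gives 96% in this assay. Compound 2, `CNCc1cn(S(=O)(=O)c2ncccc2C)c(-c2cccnc2F)c1F`, gives 54% in this assay, the lower of the two numbers; its gap to compound 1 lies beyond the scatter. Compound 3, `CNCc1cn(S(=O)(=O)c2cnccc2C)c(-c2cccnc2F)c1F`, has not yet been measured in this assay. It differs from compound 2 in one place: 4-methylpyridin-3-yl in place of 3-methylpyridin-2-yl on a sulfonyl sulfur. The two compounds are built from the same atoms, joined differently, and the change sits on the sulfonyl sulfur. Going by the values given here, no measured pair of compounds shows a change of this kind, so no step of known size is available to lean on. The read-out for compound 3 is therefore expected to stay close to that of compound 2, with no clear direction. Compound 3 is estimated to give about 55% in this assay, within a range from 25% to 85%. That estimate means an expected step of a number 1 percentage points higher from compound 2 to compound 3 (within the scatter), which is expected to lie within the scatter.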

Compound 3, a percentage reported as inhibition, in the whole organism at one dose (the size of the read-out at that dose, not a potency): 98%
Compound 3: middle estimate off by 43 percentage points, on the low side, and the stated range ends below it.
By their numbers in this assay, from the lowest: compound 2; then compounds 1 and 3 (each within the scatter of the next).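

In this assay, replacing 3-methylpyridin-2-yl with 4-methylpyridin-3-yl on the sulfonyl sulfur gives a number 44 percentage points higher from compound 2 to compound 3 (beyond the scatter). The two groups match in every count listed for them, including heavy atoms and hydrogen-bond acceptors, so this result shows that a large step can arise here from how the same atoms are joined, something the earlier compounds could not show. Nothing measured here explains why this rearrangement has such a large effect.

Going by these compounds alone, with only this one pair, it remains open whether the step follows the position of the ring nitrogen, the position of the methyl group, or the two together. A plain phenyl ring on the sulfonyl sulfur, or a methoxy group in place of the methyl, would help separate these possibilities.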